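Thiophene in place of methylphenyl on the carbonyl of compound 1

A few compounds are considered here, and "the series" means these few. Any claim that something is new, unique, unknown or untested is made for them only; others in the source may bear on it.

Compound 1 `Cc1ccccc1C(=O)/C=C1\Nc2ccccc2OC1=O` was examined in an ADME assay on Vero cells (Chlorocebus sabaeus) for cytotoxicity, read by MTT assay, with a stated time of 72 h; a higher number here means that more compound is tolerated, a lower number that less compound is tolerated. For compound 1 the reported result of > 1790000 nM is a limit of the assay rather than a number, and it is the one described as the limit of > 1790000 nM in this assay, at which 1 of the 3 values shown sits. Compound 2 `CN1C(=O)/C(=C/c2ccccc2Cl)Oc2ccccc21` has no result in this assay, recorded as "not determined" (no result reported). Compound 3 `O=C(NNC(=O)c1ccncc1)C(=O)Nc1ccc(Cl)cc1O` gives 1170000 nM in this assay. Compound 4 `O=C1Oc2ccccc2N/C1=C\C(=O)c1cccs1` differs from compound 1 in one place: thiophen-2-yl in place of 2-methylphenyl on a carbonyl carbon. Going by the values given here, no measured step of this kind is available here, so the step is expected to stay within the usual scatter, with the estimated step being an at least 1.1-fold lower number from compound 1 to compound 4 (0.07 log units; that floor lies within the scatter). In this assay compound 4 is expected to give about 1500000 nM, between 500000 nM and 3000000 nM.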

Compound 4, half-maximal cytotoxic concentration: > 1840000 nM
Compound 4 ended at the assay's limit; the forecaster's own chance of this, stated with the estimate: 50%; middle value at least 1.2-fold (0.08 log units) away from the limit.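

Going by these compounds alone, no step from compound 1 to compound 4 can be read in this assay, as both results are limits rather than numbers. The compounds shown leave open whether thiophen-2-yl in place of 2-methylphenyl changes how much compound is tolerated.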